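Cyclobutyl to pyridin-4-yl on the carbonyl carbon

A few compounds are considered here, and "the series" means these few. Any claim that something is new, unique, unknown or untested is made for them only; others in the source may bear on it.

In an ADME assay on Vero cells (Chlorocebus sabaeus) for cytotoxicity, read by MTT assay, with a stated time of 48 h (on this read-out higher numbers stand for weaker inhibition and lower numbers for stronger inhibition), compound 3 `O=C(OC1CCC(CN2CCN(c3cc(=O)c4cc(C(F)(F)F)cc([N+](=O)[O-])c4s3)CC2)CC1)C1CCC1` gives > 64 ug/mL, which is a limit and not a number. Compound 1 `Cc1cccc(C(=O)OC2CCC(CN3CCN(c4cc(=O)c5cc(C(F)(F)F)cc([N+](=O)[O-])c5s4)CC3)CC2)c1` gives > 64 ug/mL, which is also a limit. Together they form (the limit of > 64 ug/mL in this assay, at which 2 of the 3 values shown sit). Compound 2 `CS(=O)(=O)NC1CCC(CN2CCN(c3cc(=O)c4cc(C(F)(F)F)cc([N+](=O)[O-])c4s3)CC2)CC1` gives an actual number, 48.5 ug/mL.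

Compound 4 `O=C(OC1CCC(CN2CCN(c3cc(=O)c4cc(C(F)(F)F)cc([N+](=O)[O-])c4s3)CC2)CC1)c1ccncc1` has pyridin-4-yl in place of cyclobutyl on a carbonyl carbon.

For the measured compounds named here, the only measured change on this carbonyl carbon, cyclobutyl in place of 3-methylphenyl, is a step that the two limits leave unreadable from compound 1 to compound 3, so it offers no size to carry over. The other two steps, an at least 1.3-fold lower number from compound 1 to compound 2 (0.12 log units; that floor lies within the scatter) and an at least 1.3-fold higher number from compound 2 to compound 3 (0.12 log units; that floor lies within the scatter), exchange the whole group on the saturated ring carbon, and neither shows a change beyond the scatter. On this evidence, the expected step, a number no higher from compound 3 to compound 4 (the limit leaves the size open), is none beyond the scatter in this assay. Compound 4 is estimated at 64 ug/mL, with an expected range from 35 ug/mL to 128 ug/mL.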

Compound 4, half-maximal inhibitory concentration: > 64 ug/mL
Compound 4 gave a limit, no number (the forecaster's own chance of this, stated with the estimate: 65%); the middle value sits exactly at the limit.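

In this assay compound 4 gives > 64 ug/mL, which is a limit and not a number. A pyridin-4-yl group on this carbonyl carbon, an aromatic ring with a ring nitrogen, therefore stays at the same limit as the cyclobutyl of compound 3 and the 3-methylphenyl of compound 1: the limit of > 64 ug/mL in this assay, at which 3 of the 4 values shown sit. For the compounds shown here, the one readable step, ((pyridin-4-yl)carbonyl)oxy in place of methanesulfonamido on a saturated ring carbon, is an at least 1.3-fold higher number from compound 2 to compound 4 (0.12 log units; that floor lies within the scatter), while the steps among the three compounds at the limit cannot be read.

From the compounds shown here alone, how far apart compounds 1, 3 and 4 really lie stays open, as none of them has an actual number here. Also open, going by these compounds, is whether a longer chain or a ring carrying a carboxylic acid on this carbonyl carbon would give a number rather than a limit.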